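Small Ring in Place of Isopropyl on the Amide

The compounds below may be only part of what the source reports. "The series", "measured", "known", "first", "only" and "open" are said of these compounds alone.

Compound 1 `CC(C)C(=O)N1CC2CC(C1)N2` carries an isopropyl group on the carbonyl carbon of its amide. In an assay on SH-EP1 cells for agonist activity at Neuronal acetylcholine receptor; alpha4/beta2 (Homo sapiens), read by FLIPR and calcium flux (a lower number here means a smaller maximal response, a higher number a larger maximal response), compound 1 gives 86%. Compound 2 `O=C(C1CC=CC1)N1CC2CC(C1)N2` shares the core with a different acyl group, and in this assay compound 2 gives 93%. Of the two numbers that of compound 1 is the smaller, yet the gap to compound 2 lies within the scatter, so the data do not separate them. Compound 3 `C[C@@H]1C[C@H]1C(=O)N1CC2CC(C1)N2` has not yet been measured. It differs from compound 1 by 2-methylcyclopropyl in place of isopropyl on a carbonyl carbon. For the measured compounds named here, no step between measured compounds shows what this change does. Because compound 1 gives 86% and compound 2 gives 93% with another acyl group, the acyl position appears to accept change without loss. The step of a number 2 percentage points higher from compound 1 to compound 3 (within the scatter) is therefore expected to stay within the scatter. For compound 3 the estimated value in this assay is 88%, with a range from 70% to 102%.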

Compound 3, largest response reached (Emax), in percent of the reference or control that the assay uses: 110%
For compound 3 the middle estimate is 22 percentage points below the measured one, outside the stated range (above it).
By their numbers in this assay, from the lowest: compounds 1 and 2 (each within the scatter of the next); then compound 3.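

In this assay the change to 2-methylcyclopropyl in place of isopropyl on a carbonyl carbon gives a number 24 percentage points higher from compound 1 to compound 3 (beyond the scatter), so this position does more than accept a new acyl group: the group chosen there can shift the maximal response by more than the scatter. Compound 1 and compound 2 could not be told apart, and only compound 3 stands clear of both. Nothing available explains why this change has such an effect.

The compounds shown leave open whether the gain goes with the three-membered ring itself or with its methyl, and a plain cyclopropyl group on the same carbonyl carbon would address that. Also open, going by these compounds, is how the other arrangements of the 2 defined stereocentres would respond, and whether a longer chain such as n-butyl would hold the response.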